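Chloro on the phenyl of compound 1: a cytotoxicity estimate

The compounds below may be only part of what the source reports. "The series", "measured", "known", "first", "only" and "open" are said of these compounds alone.

Measured in an ADME assay on NIH3T3 cells (Mus musculus) for cytotoxicity, read by MTT assay; on this read-out higher numbers stand for weaker inhibition and lower numbers for stronger inhibition:
Compound 1 `N#Cc1c(-c2ccccc2)c(C#N)c(=O)n(/N=C/c2cn(-c3ccccc3)nc2-c2ccccc2)c1N` at 180 ug/mL
Compound 2 `N#Cc1c(-c2ccccc2O)c(C#N)c(=O)n(/N=C/c2cn(-c3ccccc3)nc2-c2ccccc2)c1N` at 162 ug/mL
Compound 3 `N#Cc1c(-c2ccc(O)cc2)c(C#N)c(=O)n(/N=C/c2cn(-c3ccccc3)nc2-c2ccccc2)c1N` at 110 ug/mL

Compound 1 stands level with its two measured relatives, as a 1.1-fold lower number from compound 1 to compound 2 (0.05 log units; within the scatter) and a 1.6-fold lower number from compound 1 to compound 3 (0.21 log units; within the scatter) both lie within the scatter. Compound 4 `N#Cc1c(-c2cccc(Cl)c2)c(C#N)c(=O)n(/N=C/c2cn(-c3ccccc3)nc2-c2ccccc2)c1N` differs from it by chloro in place of hydrogen on an aromatic carbon, turning phenyl to 3-chlorophenyl (chloro in place of hydrogen on an aromatic carbon). For the measured compounds named here, no chloro compound has been measured, so only the two hydroxy steps from compound 1 bear on this change, and neither moved the number beyond the scatter. The expected step, a 1.2-fold lower number from compound 1 to compound 4 (0.08 log units; within the scatter), therefore has no firm direction and stays within the scatter. Compound 4 is estimated at 150 ug/mL, with an expected range from 75 ug/mL to 280 ug/mL.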

Compound 4, half-maximal inhibitory concentration: 52 ug/mL
Beside the measured number, compound 4's estimate is 2.9-fold (0.46 log units) above it; the whole stated range lies above it.
By their numbers in this assay, from the lowest: compound 4; then compounds 3, 2 and 1 (each within the scatter of the next).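

In this assay, this position on the phenyl proved able to carry a change beyond the scatter, which neither hydroxy step had done: chloro in place of hydrogen gave 3-chlorophenyl (a 3.5-fold lower number from compound 1 to compound 4 (0.54 log units; beyond the scatter)). Compound 4 also stands apart from both hydroxy compounds (a 2.1-fold lower number from compound 3 to compound 4 (0.33 log units; beyond the scatter); a 3.1-fold lower number from compound 2 to compound 4 (0.49 log units; beyond the scatter)). No evidence is available on what lies behind this shift.

On these data alone, it remains open whether chloro would give a similar number at another place on this ring. Nor do the compounds shown tell whether fluoro, bromo or an amine at this position would match chloro.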